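From 3-chlorophenyl to 4-cyanophenyl on a shared core

A few compounds are considered here, and "the series" means these few. Any claim that something is new, unique, unknown or untested is made for them only; others in the source may bear on it.

Of the compounds shown here, three with a shared core have been tested in a functional assay on Raji cells (Homo sapiens) for cytotoxicity, read by CCK-8 assay, with a stated time of 24 h; on this read-out higher numbers stand for weaker inhibition and lower numbers for stronger inhibition: compound 1 `C=CC(=O)N1C(=O)CC(c2ccc(Cl)cc2)Sc2ccccc21`, compound 2 `C=CC(=O)N1C(=O)CC(c2cccs2)Sc2ccccc21` and compound 3 `C=CC(=O)N1C(=O)CC(c2cccc(Cl)c2)Sc2ccccc21`. Compound 1 gives 18400 nM and compound 2 gives 659000 nM. Compound 3, at 47100 nM, lies between these two values, closer to the first.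

The next compound, compound 4 `C=CC(=O)N1C(=O)CC(c2ccc(C#N)cc2)Sc2ccccc21`, has 4-cyanophenyl in place of 3-chlorophenyl on a saturated ring carbon.

Three measured steps changed the group on this same carbon. Between the two chlorophenyl compounds, the change was modest: a 2.6-fold higher number from compound 1 to compound 3 (0.41 log units; beyond the scatter). Replacing either with thiophen-2-yl made a large difference: a 36-fold higher number from compound 1 to compound 2 (1.55 log units; beyond the scatter) and a 14-fold lower number from compound 2 to compound 3 (1.15 log units; beyond the scatter). Among the compounds with values here, compound 4 keeps a substituted phenyl ring, so the modest step is the closer guide, but no measured compound carries a nitrile and the direction remains open.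

The estimated change is a 1.0-fold lower number from compound 3 to compound 4 (0.02 log units; within the scatter), so no step beyond the scatter is expected in this assay. The expected value for compound 4 is 45000 nM, within an estimated range of 12000 nM to 200000 nM.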

Compound 4, half-maximal inhibitory concentration: 84500 nM
For compound 4 the middle estimate is 1.9-fold (0.27 log units) below the measured one; the measured number falls inside the stated range.
By their numbers in this assay, from the lowest: compound 1; then compounds 3 and 4 (each within the scatter of the next); then compound 2.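

In this assay, 4-cyanophenyl on this carbon reads much like 3-chlorophenyl, so a nitrile can stand on the phenyl ring here without a step beyond the scatter (a 1.8-fold higher number from compound 3 to compound 4 (0.25 log units; within the scatter)). The comparison with compound 1 adds something new: with 4-chlorophenyl as the starting group, cyano in place of chloro on an aromatic carbon does give a step beyond the scatter (a 4.6-fold higher number from compound 1 to compound 4 (0.66 log units; beyond the scatter)), and 4-cyanophenyl also separates from thiophen-2-yl (a 7.8-fold lower number from compound 2 to compound 4 (0.89 log units; beyond the scatter)). Nothing given here accounts for these differences.

A 3-cyanophenyl compound would show whether the step from compound 1 belongs to the nitrile alone or also depends on where it sits on the ring. As far as these compounds go, how a methoxy group, an amine or a carboxylic acid on this phenyl ring would read remains open.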